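A few compounds are considered here, and "the series" means these few. Any claim that something is new, unique, unknown or untested is made for them only; others in the source may bear on it.

Measured so far in an assay on HeLa cells for inhibition of sphingosine-1-phosphate transporter SPNS2 (Mus musculus), read by LC-MS, tested at 2 uM; a higher number here means more inhibition at the concentration tested (going by the name of the read-out), a lower number less inhibition:
compound 1 `CCCCCCCCCCc1ccc(-c2noc(CC3CNC3)n2)cc1` gives 63%
compound 2 `CCCCCCCCCCc1ccc(-c2noc(C3CCNCC3)n2)cc1` gives 66%
compound 3 `CCCCCCCCCCc1ccc(-c2noc(CN3CCNCC3)n2)cc1` gives 19%

Compound 3 stands lowest of the three numbers in this assay; compound 1 and compound 2 both lie well above it, and the gap between those two is within the scatter.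

Compound 4 `CCCCCCCCCCc1ccc(-c2noc([C@@H](N)CCCN)n2)cc1` differs from compound 3 by 1,4-diaminobutyl in place of (piperazin-1-yl)methyl on an aromatic carbon. Among the compounds with values here, the steps that bear on this are a number 44 percentage points lower from compound 1 to compound 3 (beyond the scatter) and a number 47 percentage points lower from compound 2 to compound 3 (beyond the scatter), both large drops on arriving at the (piperazin-1-yl)methyl group. Within the data shown here, compound 4 leaves that group behind, so an upward step in this assay is expected, though no measured step covers an acyclic 1,4-diaminobutyl and the size is uncertain. Compound 4 is estimated at 52%, range 20% to 80%, an expected step of a number 33 percentage points higher from compound 3 to compound 4 (beyond the scatter).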

Compound 4, a percentage reported as inhibition, at one concentration (the size of the read-out at that concentration, not a potency): 40%
Compound 4: the middle estimate sits 12 percentage points above what was measured, within the range that was stated.
By their numbers in this assay, from the lowest: compound 3; then compound 4; then compounds 1 and 2 (each within the scatter of the next).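

In this assay the open chain gives an intermediate reading at this position: there is a number 21 percentage points higher from compound 3 to compound 4 (beyond the scatter) but also a number 26 percentage points lower from compound 2 to compound 4 (beyond the scatter) and a number 23 percentage points lower from compound 1 to compound 4 (beyond the scatter) for the same group. A ring in this group is therefore not needed to exceed compound 3, yet 1,4-diaminobutyl does not reach piperidin-4-yl or (azetidin-3-yl)methyl. Nothing available explains these differences.

Still open, going by these compounds, is which of the two amines in the chain carries the gain. A 4-aminobutyl chain with a single terminal amine, or the opposite configuration at the stereocentre, would test this.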